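The source may report more compounds than this note shows. Statements on the series, on what has been measured and on what is new or still open speak of the compounds shown alone.

Three compounds have been measured in a functional assay (trachea) with Rattus norvegicus as the target; on this read-out lower numbers stand for lower potency and higher numbers for higher potency (the scale is a negative logarithm):
compound 1 `CC(=O)c1ccc2c(c1)C(n1ccccc1=O)=CC(C)(C)O2` gives 6.65;
compound 2 `CC1(C)C=C(n2ccccc2=O)c2cc(C(=O)c3ccccc3)ccc2O1` gives 6.21;
compound 3 `CC1(C)C=C(n2ccccc2=O)c2cc(C(=O)c3ccco3)ccc2O1` gives 5.92.

Compound 3 holds the lowest of the three numbers in this assay; compound 2 lies nearest to it, the two differing only within the scatter, while compound 1 stands furthest above it, beyond the scatter. Compound 4 `CC1(C)C=C(n2ccccc2=O)c2cc(C(=O)c3ccc([N+](=O)[O-])cc3)ccc2O1` has not yet been measured. It differs from compound 3 in one place: 4-nitrophenyl in place of furan-2-yl on a carbonyl carbon. For the measured compounds named here, no measured step exchanges furan-2-yl for 4-nitrophenyl, so the steps that bear on it do so indirectly. a number 0.44 log units lower from compound 1 to compound 2 (beyond the scatter) and a number 0.73 log units lower from compound 1 to compound 3 (beyond the scatter) show that either aromatic group in place of methyl on the carbonyl carbon lowers the number modestly, and a number 0.29 log units lower from compound 2 to compound 3 (within the scatter) shows that swapping one aromatic group for the other moves it only within the scatter. A 4-nitrophenyl is a third aromatic group at the same place. For compound 4 the expected step is therefore a number 0.23 log units higher from compound 3 to compound 4 (within the scatter), within the scatter. Compound 4 is thus estimated at 6.15 in this assay, with a range from 5.6 to 6.7.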

Compound 4, logarithm of the reciprocal of the active concentration, log(1/C): 6.09
Estimate against measurement, compound 4: 0.06 log units above, within the range that was stated.
By their numbers in this assay, from the lowest: compounds 3, 4 and 2 (each within the scatter of the next); then compound 1.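

In this assay, the third aromatic group on the carbonyl carbon falls in with the first two: replacing methyl gives a number 0.56 log units lower from compound 1 to compound 4 (beyond the scatter), whereas exchanging furan-2-yl for 4-nitrophenyl gives a number 0.17 log units higher from compound 3 to compound 4 (within the scatter). Placing nitro in place of hydrogen on an aromatic carbon of the phenyl group gives a number 0.12 log units lower from compound 2 to compound 4 (within the scatter), so compound 2, compound 3 and compound 4 cannot be separated in this assay, and all three stand apart from compound 1 at this position. No measurement is available here that would account for these steps.

The compounds shown leave open whether an ethyl group or a longer chain in place of methyl on the carbonyl carbon would stay level with compound 1, and whether an amine or a carboxylic acid in place of nitro would move the number beyond the scatter. They also leave open whether the carbonyl itself is needed, as every compound shown carries it.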